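The source may report more compounds than this note shows. Statements on the series, on what has been measured and on what is new or still open speak of the compounds shown alone.

Measured so far:
- compound 1 `COc1ccc(Cl)cc1S(=O)(=O)Nc1ccc(-c2nc3ccccc3o2)cc1`: 75000 nM
- compound 2 `Cc1ccc(S(=O)(=O)Nc2ccc3oc(-c4ccccc4)nc3c2)cc1`: 75000 nM
- compound 3 `O=S(=O)(Nc1ccc2oc(-c3ccccc3)nc2c1)c1ccc(Cl)cc1`: 65000 nM

Three sulfonamides have been tested in an ADME assay on HEK293 cells (Homo sapiens) for cytotoxicity, read by resazurin assay, with a stated time of 48 h; a lower number here means that less compound is tolerated, a higher number that more compound is tolerated. Compound 1 gives 75000 nM, and compound 2 gives 75000 nM, so the two stand level at the digits shown and together form the highest pair of the three. Within the data shown here, compound 3, with 65000 nM, lies nearest below them; the only one-place step among them, a 1.2-fold lower number from compound 2 to compound 3 (0.06 log units; within the scatter), is within the scatter, so all three numbers are in practice indistinguishable.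

The unmeasured compound 4 `O=S(=O)(Nc1ccc(-c2nc3ccccc3o2)cc1)c1ccc(Cl)c(Cl)c1` departs from compound 1 on the sulfonyl sulfur: 3,4-dichlorophenyl in place of 5-chloro-2-methoxyphenyl on a sulfonyl sulfur. Among the measured compounds shown here, no measured pair exchanges the whole aryl group on that sulfur, so no step bears on this change directly. The closest comparison is the substituent swap on the sulfonyl aryl in the step from compound 2 to compound 3, which moved the number by a 1.2-fold lower number from compound 2 to compound 3 (0.06 log units; within the scatter), within the scatter. On that basis a step of no more than the scatter is expected in this assay, with no clear direction.

Compound 4 is therefore estimated at 70000 nM, in a range from 35000 nM to 140000 nM, an expected step of a 1.1-fold lower number from compound 1 to compound 4 (0.03 log units; within the scatter).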

Compound 4, half-maximal cytotoxic concentration: > 100000 nM
Compound 4: no number, only a limit; the forecaster's own chance of this, stated with the estimate: 25%; middle value at least 1.4-fold (0.15 log units) away from the limit.
By their numbers in this assay, from the lowest: compounds 3, 1 and 2 (each within the scatter of the next). At a limit, above all of these: compound 4.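

Compound 4 gives > 100000 nM in this assay, and that value is a limit of the assay, not a number. The change on the sulfonyl sulfur, 3,4-dichlorophenyl in place of 5-chloro-2-methoxyphenyl, gives an at least 1.3-fold higher number from compound 1 to compound 4 (0.12 log units; that floor lies within the scatter), so only a floor for the step is known, and that floor does not by itself set compound 4 apart from compound 1. What the earlier compounds did not show is that the whole aryl group on this sulfur can be exchanged, not just one substituent on it, with no fall in the number, and that the reading here ends at the top of the range the assay reports: the limit of > 100000 nM in this assay, at which 1 of the 4 values shown sits.

The compounds shown leave open how far beyond the limit compound 4 lies, and so whether this change moves the number past the scatter at all. They also leave open what an amine or a carboxylic acid on the sulfonyl aryl group would do in this assay, and whether the same exchange would read alike on the core of compound 2.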